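This account rests on a few compounds, and the source may have more. Where it says the series, first, only, none or still open, it means among the compounds named here.

Compound 3 `Cc1cc(=O)n(-c2ccccc2C(F)(F)F)nc1C(=O)Nc1ccc(Oc2ncnc3ccsc23)cc1` is the only one of the three measured compounds that gives a number in a functional assay on A549 cells (Homo sapiens) for cytotoxicity, read by MTT assay, with a stated time of 72 h; on this read-out lower numbers stand for stronger inhibition and higher numbers for weaker inhibition: compound 3 gives 8850 nM. Compound 1 `CNC(=O)c1cc(Oc2ccc(NC(=O)c3nn(-c4ccccc4C(F)(F)F)c(=O)cc3C)cc2F)ccn1` shows only a limit in this assay, namely > 40000 nM. Compound 2 `CNC(=O)c1cc(Oc2ccc(NC(=O)c3nn(-c4ccccc4OC(F)(F)F)c(=O)cc3C)cc2F)ccn1` likewise shows only a limit in this assay, namely > 40000 nM. Compound 4 `Cc1cc(=O)n(-c2ccccc2OC(F)(F)F)nc1C(=O)Nc1ccc(Oc2ncnc3ccsc23)cc1` is not yet measured; it differs from compound 3 by trifluoromethoxy in place of trifluoromethyl on an aromatic carbon. The same exchange was made once before, but the step that the two limits leave unreadable from compound 1 to compound 2 cannot be read because of the limit of > 40000 nM in this assay, at which 2 of the 3 values shown sit. Among the compounds with values here, no measured step therefore tells how large a change to expect in this assay from this exchange, in either direction. Compound 4 is expected at 10000 nM, between 3000 nM and 40000 nM. The step of a 1.1-fold higher number from compound 3 to compound 4 (0.05 log units; within the scatter) is expected to stay within the scatter of repeated measurements.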

Compound 4, half-maximal inhibitory concentration: 10100 nM
For compound 4 the middle estimate is 1.0-fold (0.00 log units) below the measured one; the measured number falls inside the stated range.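

In this assay the exchange of trifluoromethyl for trifluoromethoxy at this position now has a size that can be read: a 1.1-fold higher number from compound 3 to compound 4 (0.06 log units; within the scatter). On the core of compound 3, 2-(trifluoromethyl)phenyl and 2-(trifluoromethoxy)phenyl thus cannot be told apart in this read-out. The earlier pair with the same exchange could not show this because its step cannot be read: the limit of > 40000 nM in this assay, at which 2 of the 4 values shown sit.

From the compounds shown here alone, whether the exchange gives a similar step on the core of compound 1 remains open. So does what an amine or a carboxylic acid would do at this position.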